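Chloro entering the core of compound 3

The source may report more compounds than this note shows. Statements on the series, on what has been measured and on what is new or still open speak of the compounds shown alone.

Measured so far:
compound 1, `ClCc1ccc(Cn2cnc3c(Cl)ncnc32)cc1` — 10200 nM
compound 2, `ClCc1ccccc1Cn1cnc2c(Cl)nc(Cl)nc21` — 1170 nM
compound 3, `ClCc1cccc(Cn2cnc3c(Cl)ncnc32)c1` — 3460 nM

In a functional assay on Hs-578T cells (Homo sapiens) for cytotoxicity, read by sulforhodamine B assay, with a stated time of 48 h (on this read-out lower numbers stand for stronger inhibition of growth and higher numbers for weaker inhibition of growth), compound 3 gives 3460 nM, the second highest of the three numbers. Compound 1 lies nearest with 10200 nM, a higher number beyond the scatter; compound 2 lies furthest with 1170 nM, a lower number beyond the scatter. No pair among these three differs in only one place, so no single step can be read off them.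

Compound 4, `ClCc1cccc(Cn2cnc3c(Cl)nc(Cl)nc32)c1`, is yet to be measured in this assay. It differs from compound 3 by chloro in place of hydrogen on an aromatic carbon. Compound 2 differs from compound 3 in more than one place. Still, it carries a chloro group at that same kind of place, and compound 2 gives 1170 nM. The numbers of compound 2 and compound 3 are all that can be set side by side here. On that basis the step is expected to be a 2.3-fold lower number from compound 3 to compound 4 (0.36 log units; beyond the scatter). Compound 4 is accordingly estimated at 1500 nM, with a range of 500 nM to 4500 nM.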

Compound 4, concentration for 50% growth inhibition: 1990 nM
Compound 4: middle estimate off by 1.3-fold (0.12 log units), on the low side, and the stated range covers the measured number.
By their numbers in this assay, from the lowest: compounds 2, 4 and 3 (each within the scatter of the next, the first and the last beyond it); then compound 1.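

In this assay the series now has its first step in a single place: chloro in place of hydrogen on an aromatic carbon, between two ring nitrogen atoms, gives a 1.7-fold lower number from compound 3 to compound 4 (0.24 log units; within the scatter) and so cannot be told apart from repeat measurement. On this one pair, the position takes a chloro group with no change in growth inhibition beyond the scatter. Nothing on hand gives a reason for this outcome.

As far as these compounds go, whether a different group at this position, such as an amine, a methoxy group or a longer chain, would shift the number beyond the scatter remains open. Also open, from the compounds shown here alone, is what would follow if a hydroxymethyl group took the place of the chloromethyl group on compound 4.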